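One more chain link before the bromine

A few compounds are considered here, and "the series" means these few. Any claim that something is new, unique, unknown or untested is made for them only; others in the source may bear on it.

Of the compounds shown here, three sharing one core have been measured in a functional assay for antagonist activity at Adrenergic receptor alpha-1 (Rattus norvegicus); a higher number here means weaker binding, a lower number tighter binding. Compound 1 `O=c1cc(-c2ccc(Cl)cc2)oc2cc(OCCCCN3CCN(c4ccccc4)CC3)ccc12` gives 12.2 nM. Compound 2 `O=c1cc(-c2ccccc2)oc2cc(OCCBr)ccc12` gives 127 nM, and compound 3 `O=c1cc(-c2ccc(Cl)cc2)oc2cc(OCCBr)ccc12` gives 119 nM. Among these three numbers compound 2 stands highest; compound 3 lies closest to it and compound 1 lies furthest away. Among the measured compounds shown here, the one measured step, from compound 2 to compound 3, is a 1.1-fold lower number from compound 2 to compound 3 (0.03 log units; within the scatter) and comes with chloro in place of hydrogen on an aromatic carbon.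

The new compound 4 `O=c1cc(-c2ccccc2)oc2cc(OCCCBr)ccc12` has not yet been measured. It differs from compound 2 by bromomethyl in place of bromo on a saturated chain carbon, two bonds along the chain from an oxygen on an aromatic ring, so the 2-bromoethoxy becomes a 3-bromopropoxy. For the measured compounds named here, no measured step tests a change of this kind: the single step that has been measured alters a ring and leaves the chain untouched. Compound 1 carries a longer chain that ends in a phenylpiperazine rather than a bromine, and its lower number cannot be pulled apart into a chain effect and an end-group effect. With nothing to anchor a direction, the expectation for compound 4 is a step of a 1.3-fold lower number from compound 2 to compound 4 (0.10 log units; within the scatter), within the scatter, and an estimated value of 100 nM, with a range from 40 nM to 280 nM.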

Compound 4, dissociation constant: 390 nM
The estimate for compound 4 lay 3.9-fold (0.59 log units) below the measured number; measured number above the stated range.
By their numbers in this assay, from the lowest: compound 1; then compounds 3 and 2 (each within the scatter of the next); then compound 4.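

In this assay the change from 2-bromoethoxy to 3-bromopropoxy comes to a 3.1-fold higher number from compound 2 to compound 4 (0.49 log units; beyond the scatter) and so, unlike the chloro swap on the ring, it clears the usual scatter. The bromine stays at the end of the chain and only the chain grows by one carbon, yet this is enough to shift the number toward weaker binding, so this position responds to chain length even with the end group unchanged. No available evidence bears on why the added carbon has this effect.

Only these two bromo chain lengths can be compared, so a longer chain such as a 4-bromobutoxy might continue this rise, level off or reverse it. From the compounds shown here alone, it also remains open whether the same chain change would act alike with an amine such as a phenylpiperazine at the chain end, and how much of the value of compound 1 at 12.2 nM belongs to its chain and how much to that end group.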